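Methyl for hydrogen on a ring nitrogen: clearance notes

This account rests on a few compounds, and the source may have more. Where it says the series, first, only, none or still open, it means among the compounds named here.

Measured so far:
compound 1, `CNc1nc(NC)nc(NC2(C#N)CCCCC2)n1`, gives 210 mL/min/kg
compound 2, `CCCC(C#N)(CCC)Nc1nc(NC)nc(-n2cncn2)n1`, gives 32 mL/min/kg
compound 3, `CCC(C)(C#N)Nc1nc(NC)nc(-n2cncn2)n1`, gives 32 mL/min/kg

In an ADME assay on microsomes from liver (Rattus norvegicus) for metabolic stability (a higher number here means faster removal of the compound, a lower number slower removal), compound 1 stands at the highest of the three numbers; compound 2 and compound 3 each sit lower, and the gap from either of them to compound 1 lies beyond the scatter. Compound 4, `CNc1nc(NC2(C#N)CCCCC2)nc(N(C)C)n1`, is not yet measured. It differs from compound 1 in one place: methyl in place of hydrogen on a nitrogen on an aromatic ring. Among the measured compounds shown here, no two measured compounds differ in a single place, so no measured step guides this change. The step is expected to be small, a 1.2-fold lower number from compound 1 to compound 4 (0.07 log units; within the scatter), and not beyond the scatter in either direction. For compound 4 the estimate is 180 mL/min/kg, with a range from 90 mL/min/kg to 360 mL/min/kg.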

Compound 4, clearance: 276 mL/min/kg
For compound 4 the middle estimate is 1.5-fold (0.19 log units) below the measured one; the range from low to high includes it.
By their numbers in this assay, from the lowest: compounds 2 and 3 (each within the scatter of the next); then compounds 1 and 4 (each within the scatter of the next).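

In this assay, among the compounds shown here, the change from methylamino to dimethylamino gives the first single-place step (a 1.3-fold higher number from compound 1 to compound 4 (0.12 log units; within the scatter)). At this nitrogen on an aromatic ring, methyl in place of hydrogen therefore leaves clearance within the scatter, so this one added carbon does not separate compound 1 from compound 4. No measured data at hand bear on the reason for this result. As far as these compounds go, it remains open whether an ethyl group, a longer chain or a morpholine at this nitrogen would also stay within the scatter. From the compounds shown here alone, whether the same methyl step reads alike on other compounds is also open.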